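The source may hold more compounds than are shown below. What is called first, only, known or untested is meant among the compounds shown, and "the series" means these compounds.

In a functional assay on MCF7 cells (Homo sapiens) for antiproliferative activity, with a stated time of 72 h (on this read-out lower numbers stand for stronger inhibition and higher numbers for weaker inhibition), compound 1 `Cn1c(N2N=C(c3ccccc3)CC2c2ccccc2)nc(-c2ccccc2)c(C#N)c1=O` gives 35400 nM, the higher of the two numbers at hand; compound 2 `COc1ccc(C2CC(c3ccccc3)=NN2c2nc(-c3ccccc3)c(C#N)c(=O)n2C)cc1` gives 18000 nM, and the change a 2.0-fold lower number from compound 1 to compound 2 (0.29 log units; within the scatter) stays within the scatter. Compound 3 `Cn1c(N2N=C(c3ccc(Cl)cc3)CC2c2ccccc2)nc(-c2ccccc2)c(C#N)c1=O` differs from compound 1 by chloro in place of hydrogen on an aromatic carbon. Among the compounds with values here, the only measured step, methoxy for hydrogen on a different ring, moved the number by a 2.0-fold lower number from compound 1 to compound 2 (0.29 log units; within the scatter), so a single small substituent on one of the rings has so far made no difference beyond the scatter, and no step beyond it is expected here either. Compound 3 is therefore estimated at 30000 nM, between 12000 nM and 80000 nM. For compound 3 this estimate means a step of a 1.2-fold lower number from compound 1 to compound 3 (0.07 log units; within the scatter).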

Compound 3, half-maximal inhibitory concentration: 12300 nM
For compound 3 the middle estimate is 2.4-fold (0.39 log units) above the measured one; measured number inside the range.
By their numbers in this assay, from the lowest: compounds 3, 2 and 1 (each within the scatter of the next, the first and the last beyond it).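

In this assay, within the data shown here, replacing phenyl with 4-chlorophenyl gives a 2.9-fold lower number from compound 1 to compound 3 (0.46 log units; beyond the scatter), the first step to pass the scatter. A single chloro, on an aromatic carbon para to a large group, can therefore shift the number modestly, although compound 3 remains within the scatter of compound 2. Nothing measured here explains this shift. Still open, on these data alone, is whether an amine or a carboxylic acid at this place would shift the number further or in the opposite direction. Also open, as far as these compounds go, is whether chloro would have the same effect on the ring that carries methoxy in compound 2.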